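The source may hold more compounds than are shown below. What is called first, only, known or untested is meant among the compounds shown, and "the series" means these compounds.

Measured so far in an ADME assay on HEL cells (Homo sapiens) for cytotoxicity, read by microscopy; a lower number here means that less compound is tolerated, a higher number that more compound is tolerated:
compound 1 `O=c1ccn(CCCCCOc2ccc(-c3ccccc3)cc2)c(=O)[nH]1` gives 100000 nM.
Compound 2 `CCCOC(=O)c1ccc(OCCCCCn2ccc(=O)[nH]c2=O)cc1` gives only a limit, >= 100000 nM.

Compound 2 therefore stands at the top of what this assay reports, at the limit of >= 100000 nM in this assay, at which 1 of the 2 values shown sits. Among the measured compounds shown here, the one measured step, a number no lower from compound 1 to compound 2 (the limit leaves the size open), is read against that limit and its size stays open.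

Compound 3 `O=c1ccn(CCCCCOc2ccccc2)c(=O)[nH]1` differs from compound 2 by hydrogen in place of propoxycarbonyl on an aromatic carbon. For the measured compounds named here, no measured step covers this change directly; the step from compound 1 to compound 2 only shows that tolerance did not fall. The expected step is a number no higher from compound 2 to compound 3 (the limit leaves the size open), none beyond the scatter. Compound 3 is estimated at 100000 nM, between 50000 nM and 200000 nM.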

Compound 3, minimum cytotoxic concentration: > 100000 nM
Compound 3: no number, only a limit (the forecaster's own chance of this, stated with the estimate: 70%); the middle value sits exactly at the limit.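

In this assay compound 3 gives > 100000 nM, which is a limit of the assay and not a number. Hydrogen on this aromatic carbon thus keeps the series at the top of the reported range, and a number no lower from compound 1 to compound 3 (the limit leaves the size open) is the only direction that can be read. The step between compound 2 and compound 3 cannot be read, as both values are limits: the limit of > 100000 nM in this assay, at which 1 of the 3 values shown sits.

As far as these compounds go, how far the tolerated concentrations lie past these limits stays open. So does whether an amine or a carboxylic acid on this aromatic carbon would give a lower number.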